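The compounds below may be only part of what the source reports. "The series", "measured", "known", "first", "only" and "open" are said of these compounds alone.

Measured compounds:
- compound 1, `Cc1ccc2nc(NCCCCOc3cc(O)c4c(=O)cc(-c5ccccc5)oc4c3)sc2c1`: in a functional assay on Ca-Ski cells (Homo sapiens) for cytotoxicity, read by sulforhodamine B assay, with a stated time of 48 h (on this read-out higher numbers stand for weaker inhibition and lower numbers for stronger inhibition), compound 1 gives 15.5 ug/mL
- compound 2, `O=c1cc(-c2ccccc2)oc2cc(OCCCCNc3nc4ccc([N+](=O)[O-])cc4s3)cc(O)c12`: compound 2 gives 13.2 ug/mL
- compound 3, `O=c1cc(-c2ccccc2)oc2cc(OCCCCNc3nc4ccc(Br)cc4s3)cc(O)c12`: compound 3 gives 12.4 ug/mL

Compound 3 gives the lowest of the three numbers, but its neighbours lie close: compound 2 sits at a 1.1-fold lower number from compound 2 to compound 3 (0.03 log units; within the scatter) and compound 1 at a 1.3-fold lower number from compound 1 to compound 3 (0.10 log units; within the scatter), both within the scatter, so no ordering among the three can be claimed. The three compounds share one core and differ only in the group on one aromatic carbon of the fused ring system.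

Compound 4, `O=c1cc(-c2ccccc2)oc2cc(OCCCCNc3nc4ccc(C(F)(F)F)cc4s3)cc(O)c12`, continues this series. The change from compound 3 is trifluoromethyl in place of bromo on an aromatic carbon. Among the measured compounds shown here, the steps that bear on it are those that exchanged the group at the same carbon: a 1.2-fold lower number from compound 1 to compound 2 (0.07 log units; within the scatter), a 1.3-fold lower number from compound 1 to compound 3 (0.10 log units; within the scatter) and a 1.1-fold lower number from compound 2 to compound 3 (0.03 log units; within the scatter). Each stayed within the scatter, so exchanging one group for another at this position has not moved the number in any case shown. Compound 4 is therefore expected to behave the same way, with a step of a 1.0-fold higher number from compound 3 to compound 4 (0.00 log units; within the scatter) that does not exceed the scatter. Compound 4 is estimated at 12.5 ug/mL, with a range from 7 ug/mL to 22 ug/mL.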

Compound 4, half-maximal inhibitory concentration: 11.2 ug/mL
Estimate against measurement, compound 4: 1.1-fold (0.05 log units) above; low and high end bracket the measured number.
By their numbers in this assay, from the lowest: compounds 4, 3, 2 and 1 (each within the scatter of the next).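

In this assay, trifluoromethyl brings four heavy atoms to this aromatic carbon where bromo brought one, yet the result is only a 1.1-fold lower number from compound 3 to compound 4 (0.04 log units; within the scatter), so the larger group does not shift the number beyond what repeated measurements would give. The comparisons with the other two groups read the same way, with a 1.2-fold lower number from compound 2 to compound 4 (0.07 log units; within the scatter) and a 1.4-fold lower number from compound 1 to compound 4 (0.14 log units; within the scatter), and the second of these is the largest step among the compounds shown, yet it too stays inside the scatter. The position has now carried methyl, nitro, bromo and trifluoromethyl with no exchange among them separating any pair, and nothing at hand offers an explanation for this flat result.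

As far as these compounds go, it remains open whether a group of another kind on this carbon, such as an amine or a carboxylic acid, would also stay within the scatter or would be the first to move the number. Also open, from the compounds shown here alone, is whether a longer chain linking the two halves of the molecule, or a change elsewhere on the shared core, would have a larger effect; every compound here differs only at this one carbon.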